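A furan-2-yl swap on a stable pair

The compounds below may be only part of what the source reports. "The series", "measured", "known", "first", "only" and "open" are said of these compounds alone.

Of the compounds shown here, two with one shared core have been read in an ADME assay on microsomes from liver (Mus musculus) for metabolic stability, read by LC-MS, with NADPH named in the record, with a stated time of 60 min, tested at 1 uM, in the absence of a further agent; on this read-out higher numbers stand for a more stable compound and lower numbers for a less stable compound. Compound 1 (`COc1cc(-c2c(C)nc3c(N4CC[C@@H](NC(C)=O)C4)cc(C)nn23)cc(OC)c1OC`) gives > 95%, which is a limit of the assay and not a number. Compound 2 (`COc1ccc(-c2c(C)nc3c(N4CC[C@@H](NC(C)=O)C4)cc(C)nn23)cc1F`) gives > 95%, again only a limit. Compound 2 therefore has no exact position, and the record so far amounts to the limit of > 95% in this assay, at which 2 of the 2 values shown sit.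

Compound 3 (`CC(=O)N[C@@H]1CCN(c2cc(C)nn3c(-c4ccco4)c(C)nc23)C1`) carries furan-2-yl in place of 3-fluoro-4-methoxyphenyl on an aromatic carbon of a five-membered aromatic ring with 2 nitrogen: furan-2-yl in place of 3-fluoro-4-methoxyphenyl on an aromatic carbon. Among the measured compounds shown here, no measured step shows what such a change does in this assay, so the expectation is a judgement, and it points to a moderate fall. The estimated step is a number at least 13 percentage points lower from compound 2 to compound 3 (beyond the scatter), a fall beyond the usual scatter. Compound 3 is expected at 82%, with an estimated range from 60% to 97%.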

Compound 3, percent of the compound remaining: > 95%
Compound 3 gave a limit, no number; the forecaster's own chance of this, stated with the estimate: 30%; middle value at least 13 percentage points away from the limit.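

In this assay compound 3 gives > 95%, a limit of the assay and not a number. Compound 2 also sits at a limit, so no step can be read between compound 2 and compound 3. The compounds shown leave open how compound 1, compound 2 and compound 3 rank on this read-out, because all of them share one limit: the limit of > 95% in this assay, at which 3 of the 3 values shown sit.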